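This account rests on a few compounds, and the source may have more. Where it says the series, first, only, none or still open, it means among the compounds named here.

Compounds measured so far:
compound 1, `CCCNC(=O)C1C(C(=O)O)[C@@H]2CC[C@H]1O2`, with 10000 nM;
compound 2, `O=C(O)C1C(C(=O)NCC2Cc3ccsc3CO2)[C@H]2CC[C@@H]1O2`, with 10000 nM;
compound 3, `Cc1cc(C)c(NC(=O)C2C(C(=O)O)[C@@H]3CC[C@H]2O3)c(C)c1`, with 10000 nM.

All three share one core and differ only in the group attached through the amide nitrogen. In an ADME assay on A-431 cells (Homo sapiens) for cytotoxicity, read by MTT assay, with a stated time of 72 h (on this read-out lower numbers stand for stronger inhibition of growth and higher numbers for weaker inhibition of growth), compound 1 gives 10000 nM. In this assay compound 2 gives 10000 nM, and compound 3 gives 10000 nM. Compound 1 therefore stands level with compounds 2 and 3 at the digits reported; its nearest neighbour is compound 2 and its furthest is compound 3, and neither gap reaches beyond the scatter of the method. Whether the amide carries a propyl chain, a fused bicyclic ether or a trimethylphenyl group, the read-out is the same, so nothing in this set points to any part of the amide side chain that moves the number.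

The unmeasured compound 4, `O=C(O)CCCNC(=O)C1C(C(=O)O)[C@@H]2CC[C@H]1O2`, is reached from compound 1 by one change, (carboxy in place of hydrogen on a saturated chain carbon, three bonds along the chain from an amide-type nitrogen). For the measured compounds named here, no step between two measured compounds describes such a change, so the expectation rests on the flat picture above: the three measured amides sit at the same value, and compound 4 is expected to do the same. The step from compound 1 to compound 4 in this assay is estimated as no change at the digits printed from compound 1 to compound 4 (within the scatter), that is, no change beyond the scatter. Compound 4 is expected to give 10000 nM, within a range from 5000 nM to 20000 nM.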

Compound 4, concentration for 50% growth inhibition: 10000 nM
Compound 4: the middle estimate sits on the measured number at the digits printed, and the stated range covers the measured number.
By their numbers in this assay, from the lowest: compounds 1, 2, 3 and 4 (each within the scatter of the next).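

In this assay, for the compounds shown here, the pair of compound 1 and compound 4 gives the first readable step between two compounds that differ in one place, and that step is no change at the digits printed from compound 1 to compound 4 (within the scatter). Going by these compounds alone, it shows that the change from propyl to 3-carboxypropyl on the amide of compound 1 leaves the read-out unmoved; the earlier compounds, which differ from one another by whole amide groups, could show only a shared value and not the outcome of one defined change. Nothing measured in this set accounts for that outcome.

The compounds shown leave open whether an amine or a methyl ester in place of the carboxy on this chain, or a longer chain bearing the carboxy, would give a value other than the one these four compounds share. They also leave open whether replacing the carboxylic acid on the shared core with an ester or an amide would move the number in this assay.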